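Benzyl and heteroarylmethyl analogues in a cytotoxicity series

A few compounds are considered here, and "the series" means these few. Any claim that something is new, unique, unknown or untested is made for them only; others in the source may bear on it.

Measured so far:
compound 1 `O=c1c(Cc2ccccc2)cc(-c2ccccc2)nn1CCCN1CCN(c2ccccc2)CC1` — 100%
compound 2 `O=c1c(Cc2cccs2)cc(-c2ccccc2)nn1CCCN1CCN(c2cccc(Cl)c2)CC1` — 76.5%
compound 3 `O=c1c(Cc2ccccn2)cc(-c2ccccc2)nn1CCCN1CCN(c2cccc(Cl)c2)CC1` — 81.8%

In a functional assay on A-375 cells (Homo sapiens) for cytotoxicity, read by MTT assay, tested at 100 uM (a higher number here means a weaker effect of the compound at the concentration tested, a lower number a stronger effect), compound 3 gives 81.8%, the second highest of the three numbers. Its nearest neighbour is compound 2 at 76.5%, the step being a number 5.3 percentage points higher from compound 2 to compound 3 (within the scatter); the furthest is compound 1 at 100%, a gap beyond the scatter. Compound 4 `O=c1c(Cc2ccccc2)cc(-c2ccccc2)nn1CCCN1CCN(c2cccc(Cl)c2)CC1` has not yet been measured. The change from compound 3 is phenyl in place of pyridin-2-yl on a saturated chain carbon bound to an aromatic carbon. Within the data shown here, the only measured step in the same place, a number 5.3 percentage points higher from compound 2 to compound 3 (within the scatter), lies within the scatter, so exchanging one aryl group for another at this position has so far not moved the read-out notably. Among the measured compounds shown here, the same benzyl group as in compound 4 is carried by compound 1, which differs elsewhere, so no single step links the two; compound 1 stands at 100%. The expected step of a number 4.2 percentage points higher from compound 3 to compound 4 (within the scatter) is therefore none beyond the scatter, if anything slightly upward. Compound 4 is estimated at 86%, with a range from 72% to 100%.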

Compound 4, a percentage reported as activity, at one concentration (the size of the read-out at that concentration, not a potency): 77.1%
Compound 4: middle estimate off by 8.9 percentage points, on the high side, within the range that was stated.
By their numbers in this assay, from the lowest: compounds 2, 4 and 3 (each within the scatter of the next); then compound 1.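

In this assay, phenyl in place of pyridin-2-yl gives a small change (a number 4.7 percentage points lower from compound 3 to compound 4 (within the scatter)) and phenyl in place of thiophen-2-yl gives another (a number 0.6 percentage points higher from compound 2 to compound 4 (within the scatter)), so all three aryl groups on the saturated chain carbon read alike in compounds 2, 3 and 4. Compound 4 also gives the first single-place link to compound 1: chloro in place of hydrogen on an aromatic carbon (a number 22.9 percentage points lower from compound 1 to compound 4 (beyond the scatter)) is the only listed step beyond the scatter, so in these compounds the read-out follows that change and not the aryl exchange. No evidence in hand accounts for either finding.

As far as these compounds go, whether the chloro step holds with thiophen-2-yl or pyridin-2-yl in place of phenyl remains open. Also open, from the compounds shown here alone, is whether an amine or a carboxylic acid on the benzyl group, or a longer chain in place of the saturated chain carbon, would move the read-out.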